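Cyclobutyl to Isopropyl on the Sulfonyl Sulfur

The source may report more compounds than this note shows. Statements on the series, on what has been measured and on what is new or still open speak of the compounds shown alone.

Of the compounds shown here, three sharing one core have been measured in a functional assay on MIA PaCa-2 cells (Homo sapiens) for inhibition, read by MTT assay, with a stated time of 3 days; on this read-out lower numbers stand for stronger inhibition and higher numbers for weaker inhibition. Compound 1 `O=C([C@@H]1CCCN(S(=O)(=O)c2ccc(S(=O)(=O)N3CC[C@@H](O)C3)cc2)C1)N1CCC(F)(F)CC1` gives 135 nM, compound 2 `O=C([C@@H]1CCCN(S(=O)(=O)c2ccc(S(=O)(=O)C3CCC3)cc2)C1)N1CCC(F)(F)CC1` gives 12.6 nM, and compound 3 `CCN(CC)S(=O)(=O)c1ccc(S(=O)(=O)N2CCC[C@@H](C(=O)N3CCC(OC)CC3)C2)cc1` gives 50 nM. Compound 2 stands at the lowest number of the three, with compound 3 the nearest and compound 1 the furthest. For the measured compounds named here, the one step that was measured directly, an 11-fold lower number from compound 1 to compound 2 (1.03 log units; beyond the scatter), came with cyclobutyl in place of 3-hydroxypyrrolidin-1-yl on a sulfonyl sulfur.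

Compound 4 `CC(C)S(=O)(=O)c1ccc(S(=O)(=O)N2CCC[C@@H](C(=O)N3CCC(F)(F)CC3)C2)cc1` has not yet been measured. It differs from compound 2 in one place: isopropyl in place of cyclobutyl on a sulfonyl sulfur. Going by the values given here, no measured step exchanges one group without rings for a small carbon ring on this sulfonyl sulfur, so the change of compound 1 to compound 2 bears on it only loosely. A step of a 1.4-fold higher number from compound 2 to compound 4 (0.15 log units; within the scatter) is therefore expected, not beyond the scatter. In this assay compound 4 is estimated at 18 nM, within a range of 8 nM to 45 nM.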

Compound 4, half-maximal inhibitory concentration: 9.1 nM
Beside the measured number, compound 4's estimate is 2.0-fold (0.30 log units) above it; the range from low to high includes it.
By their numbers in this assay, from the lowest: compounds 4 and 2 (each within the scatter of the next); then compound 3; then compound 1.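

In this assay, the sulfonyl sulfur takes isopropyl as readily as cyclobutyl: the exchange gives a 1.4-fold lower number from compound 2 to compound 4 (0.14 log units; within the scatter), so the small carbon ring is not needed for a number in this range. The large gain from the hydroxylated group now appears a second time, as a 15-fold lower number from compound 1 to compound 4 (1.17 log units; beyond the scatter), so it is not tied to cyclobutyl alone but is shared by both carbon groups that take the place of 3-hydroxypyrrolidin-1-yl. Across these two groups, the presence or absence of a ring on the sulfonyl sulfur makes no difference beyond the scatter.

The compounds shown leave open whether methyl, a longer chain such as n-butyl, or a chain ending in a carboxylic acid or an amine would hold the number at this sulfur. Nothing at hand gives a measured reason for the two carbon groups reading alike or for the gain over 3-hydroxypyrrolidin-1-yl.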